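The source may hold more compounds than are shown below. What is called first, only, known or untested is meant among the compounds shown, and "the series" means these compounds.

Compound 3, `NC[C@@H]1CCN(c2cc3c(cc2F)c(=O)c(C(=O)O)cn3Cc2nc(-c3ccncc3)no2)C1`, is the point of departure. In an assay on isolated protein for inhibition of DNA topoisomerase 1 (Homo sapiens), with a stated time of 15 min (on this read-out higher numbers stand for weaker inhibition and lower numbers for stronger inhibition), compound 3 gives > 200000 nM, which is a limit of the assay rather than a measured number. Two further compounds share its core and its benzylic link to the aromatic nitrogen. Compound 1, `COc1c(N2CC[C@@H](CO)C2)c(F)cc2c(=O)c(C(=O)O)cn(Cc3ccc(-c4ccccc4)cc3)c12`, gives > 200000 nM in this assay, again a limit and not a number. Compound 2, `CN[C@@H]1CCN(c2c(F)cc3c(=O)c(C(=O)O)cn(Cc4ccc(-c5ccccc5)cc4)c3c2OC)C1`, gives 57700 nM in this assay. Among the measured compounds shown here, the one measured step, an at least 3.4-fold lower number from compound 1 to compound 2 (0.53 log units; beyond the scatter), concerns the substituent on the saturated ring and says nothing about the group carried by the chain carbon bound to the aromatic nitrogen. Compound 4, `NC[C@@H]1CCN(c2cc3c(cc2F)c(=O)c(C(=O)O)cn3Cc2cc(-c3ccccc3)no2)C1`, differs from compound 3 by 3-phenyl-1,2-oxazol-5-yl in place of 3-(pyridin-4-yl)-1,2,4-oxadiazol-5-yl on a saturated chain carbon bound to an aromatic nitrogen. For the measured compounds named here, no measured step bears directly on this exchange; the only guide is the limit of > 200000 nM in this assay, at which 2 of the 3 values shown sit, which shows how much of this small set lies beyond the range the assay can report. The estimate for compound 4 therefore stays close to that limit, and is expected at 150000 nM, with a range from 40000 nM to 500000 nM. The expected step is an at least 1.3-fold lower number from compound 3 to compound 4 (0.12 log units; that floor lies within the scatter), which would leave compound 4 among the weak inhibitors of this series.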

Compound 4, half-maximal inhibitory concentration: 58300 nM
For compound 4 the middle estimate is 2.6-fold (0.41 log units) above the measured one, within the range that was stated.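

In this assay, among the compounds shown here, the exchange on a saturated chain carbon bound to an aromatic nitrogen gives an at least 3.4-fold lower number from compound 3 to compound 4 (0.53 log units; beyond the scatter), the first measured step to bear on this place; the earlier step concerned only the substituent on the saturated ring. The exchange alters two rings at once, a five-membered aromatic ring with 3 hetero atoms giving way to one with 2, and a six-membered aromatic ring with 1 hetero atom giving way to one of carbon only, so the step cannot be assigned to either ring alone. The value of compound 3 is a limit of the assay, which makes the step a floor and not a size, and such limits still mark this small set: the limit of > 200000 nM in this assay, at which 2 of the 4 values shown sit.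

Going by these compounds, it remains open whether 3-phenyl-1,2,4-oxadiazol-5-yl or 3-(pyridin-4-yl)-1,2-oxazol-5-yl at this place would read like compound 3 or like compound 4, which would separate the two ring changes. Also open, on these data alone, is what a dimethylamino group on the phenyl ring of 3-phenyl-1,2-oxazol-5-yl would do to the read-out.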